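Replacing a Chain-End Hydroxymethyl with a Nitrogen Group

The compounds below may be only part of what the source reports. "The series", "measured", "known", "first", "only" and "open" are said of these compounds alone.

- compound 1 `CC(C)c1n[nH]c2c(NCc3ccc(-c4ccccn4)cc3)nc(SCC(N)CN)nc12` gives 480 nM
- compound 2 `CC(C)c1n[nH]c2c(NCc3ccc(-c4ccccn4)cc3)nc(SCC(O)CN3CCNCC3)nc12` gives 332 nM
- compound 3 `CC(C)c1n[nH]c2c(NCc3ccc(-c4ccccn4)cc3)nc(SCCCO)nc12` gives 109 nM

In a functional assay on HT cells (Homo sapiens) for antiproliferative activity, read by fluorescence, with a stated time of 72 h (on this read-out higher numbers stand for weaker inhibition of growth and lower numbers for stronger inhibition of growth), compound 3 has the lowest number of the three, 109 nM, and so shows the strongest inhibition of growth. The next structure, compound 4 `CC(C)c1n[nH]c2c(NCc3ccc(-c4ccccn4)cc3)nc(SCCNC(=N)N)nc12`, keeps the shared core and alters only the end of the chain on sulfur: a group of 4 heavy atoms (1 carbon, 3 nitrogen; no ring) in place of a group of 2 heavy atoms (1 carbon, 1 oxygen; no ring), on a saturated chain carbon, two bonds along the chain from a sulfur. For the measured compounds named here, no measured step makes this exact change, so the evidence is indirect. Going by the values given here, compound 3 is the only measured compound with no nitrogen in that chain, and two steps lead to it: a 4.4-fold lower number from compound 1 to compound 3 (0.64 log units; beyond the scatter), and a 3.0-fold lower number from compound 2 to compound 3 (0.48 log units; beyond the scatter). The two nitrogen-bearing chains themselves stay close: a 1.4-fold lower number from compound 1 to compound 2 (0.16 log units; within the scatter). Compound 4 puts nitrogen back into the chain, so a modest rise in this assay is expected, though three compounds are a thin guide. The expected change is a 2.6-fold higher number from compound 3 to compound 4 (0.41 log units; beyond the scatter). For compound 4 the estimate is 280 nM, with an expected range from 110 nM to 700 nM.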

Compound 4, concentration for 50% growth inhibition: 390 nM
Estimate against measurement, compound 4: 1.4-fold (0.14 log units) below; the range from low to high includes it.
By their numbers in this assay, from the lowest: compound 3; then compounds 2, 4 and 1 (each within the scatter of the next).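

In this assay the group of 4 heavy atoms at the end of the chain on sulfur does not match the hydroxymethyl end of compound 3 (a 3.6-fold higher number from compound 3 to compound 4 (0.55 log units; beyond the scatter)). It instead sits with the other two nitrogen-bearing chains (a 1.2-fold higher number from compound 2 to compound 4 (0.07 log units; within the scatter); a 1.2-fold lower number from compound 1 to compound 4 (0.09 log units; within the scatter)), both steps within the scatter, so three differently built nitrogen chains now group together, and compound 3 remains alone as the chain without nitrogen. Nothing measured here offers a reason for this gap.

Still open, going by these compounds, is whether the gap follows from nitrogen in the chain as such or from these particular groups. A single amine or a methoxy group at the same chain end, or a longer chain ending in hydroxyl, would help separate those two readings.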